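Cytotoxicity of a lignan series: pyrrolidine amide to aryltriazole

The source may report more compounds than this note shows. Statements on the series, on what has been measured and on what is new or still open speak of the compounds shown alone.

Compound 1 `COc1ccc(C[C@H]2COC(=O)[C@@H]2Cc2ccc(OCC(=O)Nc3ccc(C)cc3)c(OC)c2)cc1OC` gives 228000 nM in an ADME assay on HeLa cells (Homo sapiens) for cytotoxicity, read by MTT assay (on this read-out higher numbers stand for weaker inhibition and lower numbers for stronger inhibition), and compound 2 `COc1ccc(C[C@H]2COC(=O)[C@@H]2Cc2ccc(OCc3cn(Cc4ccc(Cl)cc4)nn3)c(OC)c2)cc1OC` gives 242000 nM. For compound 3 `COc1ccc(C[C@H]2COC(=O)[C@@H]2Cc2ccc(OCC(=O)N3CCCC3)c(OC)c2)cc1OC` the assay reports only a limit, >= 600000 nM. The step of an at least 2.6-fold higher number from compound 1 to compound 3 (0.42 log units; beyond the scatter) therefore leaves compound 3 standing at the limit of >= 600000 nM in this assay, at which 1 of the 3 values shown sits, with no number of its own. Compound 4 `COc1ccc(C[C@H]2COC(=O)[C@@H]2Cc2ccc(OCc3cn(-c4ccc(Cl)cc4)nn3)c(OC)c2)cc1OC` differs from compound 3 by 1-(4-chlorophenyl)-1H-1,2,3-triazol-4-yl in place of (pyrrolidin-1-yl)carbonyl on a saturated chain carbon bound to an oxygen on an aromatic ring. Among the measured compounds shown here, no measured step covers this exchange directly; the only step into compound 3 is an at least 2.6-fold higher number from compound 1 to compound 3 (0.42 log units; beyond the scatter), while compound 2, which also carries a triazole, gives 242000 nM. Compound 4 is thus expected to come out close to compound 2. The expected step is an at least 2.4-fold lower number from compound 3 to compound 4 (0.38 log units; beyond the scatter), downward, though its size stays uncertain since compound 3 sits only at a limit. Compound 4 is estimated at 250000 nM, between 100000 nM and 600000 nM.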

Compound 4, half-maximal inhibitory concentration: 279000 nM
Estimate against measurement, compound 4: 1.1-fold (0.05 log units) below; measured number inside the range.
By their numbers in this assay, from the lowest: compounds 1, 2 and 4 (each within the scatter of the next). At a limit, above all of these: compound 3.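

In this assay, 1-(4-chlorophenyl)-1H-1,2,3-triazol-4-yl in place of (pyrrolidin-1-yl)carbonyl gives an at least 2.1-fold lower number from compound 3 to compound 4 (0.33 log units; beyond the scatter). Against that, 4-chlorophenyl in place of 4-chlorobenzyl on an aromatic nitrogen gives a 1.2-fold higher number from compound 2 to compound 4 (0.06 log units; within the scatter), and the triazole in place of (4-methylphenyl)carbamoyl gives a 1.2-fold higher number from compound 1 to compound 4 (0.09 log units; within the scatter), so only the pyrrolidine amide stands apart among these compounds. For compound 3 the reading is a limit, not a number: the limit of >= 600000 nM in this assay, at which 1 of the 4 values shown sits.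

As far as these compounds go, it remains open whether a piperidine or morpholine amide would stand apart as compound 3 does. Also open, from the compounds shown here alone, is whether an amine or a carboxylic acid at this place would give a lower number than compound 4.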